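This account rests on a few compounds, and the source may have more. Where it says the series, first, only, none or still open, it means among the compounds named here.

Values measured in a functional assay on HT-29 cells (Homo sapiens) for inhibition, read by sulforhodamine B assay, with a stated time of 72 h (a lower number here means a stronger inhibitor, a higher number a weaker inhibitor), are as follows:

- Compound 1 `COc1ccc(C2C(O)C(=O)N2c2cc(OC)c(OC)c(OC)c2)cc1` gives 12 nM
- Compound 2 `CCSc1ccc(C2CC(=O)N2c2cc(OC)c(OC)c(OC)c2)cc1` gives 311 nM
- Compound 3 `COc1ccc(C2C(Oc3ccccc3)C(=O)N2c2cc(OC)c(OC)c(OC)c2)cc1` gives 52 nM

Compound 3 holds the middle place of the three, with a higher number than compound 1 and a lower one than compound 2. Compound 4 `COc1ccc(C2CC(=O)N2c2cc(OC)c(OC)c(OC)c2)cc1` has hydrogen in place of phenoxy on a saturated ring carbon, and the full difference is hydrogen in place of phenoxy on a saturated ring carbon at that one place. Within the data shown here, the only measured step at this carbon (a 4.3-fold higher number from compound 1 to compound 3 (0.64 log units; beyond the scatter)) was modest. Compound 2 also has hydrogen there and gives 311 nM but carries ethylthio where compound 4 has methoxy, so it is only a loose guide. A modest step toward a higher number is therefore expected in this assay although its direction is not firmly supported. The expected step is a 2.5-fold higher number from compound 3 to compound 4 (0.40 log units; beyond the scatter) overall. Compound 4 is estimated at 130 nM with an expected range from 40 nM to 400 nM as the likely span.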

Compound 4, half-maximal inhibitory concentration: 65 nM
Compound 4: the middle estimate sits 2.0-fold (0.30 log units) above what was measured; the measured number falls inside the stated range.
By their numbers in this assay, from the lowest: compound 1; then compounds 3 and 4 (each within the scatter of the next); then compound 2.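

On the saturated ring carbon, hydrogen in place of phenoxy gives a 1.3-fold higher number from compound 3 to compound 4 (0.10 log units; within the scatter) and so separates these two groups by no more than the scatter, while hydrogen in place of hydroxy gives a 5.4-fold higher number from compound 1 to compound 4 (0.73 log units; beyond the scatter) and sets hydroxy apart from hydrogen at the same carbon. On the aromatic carbon, methoxy in place of ethylsulfanyl gives a 4.8-fold lower number from compound 2 to compound 4 (0.68 log units; beyond the scatter) as a second, separate step from this compound. Nothing available accounts for either effect. On these data alone, whether an amine at the ring carbon would read like hydroxy or like hydrogen stays open. So does whether a carboxylic acid there would follow either group.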